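This account rests on a few compounds, and the source may have more. Where it says the series, first, only, none or still open, it means among the compounds named here.

The study covers compounds sharing one core, all tested in a functional assay on K562 cells (Homo sapiens) for cytotoxicity, with a stated time of 72 h; a higher number here means a weaker inhibitor, a lower number a stronger inhibitor. Compound 1 `Cc1cccc(-c2nn3c(c2-c2ccncc2)C(C)C(C)(C)C3)c1C#N` gives 92000 nM in this assay. Compound 2 `CCc1cccc(-c2nn3c(c2-c2ccnc(Nc4ccc(S(N)(=O)=O)cc4)c2)C(C)C(C)(C)C3)n1` gives 24000 nM in this assay. Compound 3 `COCC1c2c(-c3ccncc3)c(-c3cccc(C)n3)nn2CC1(C)C` returns > 100000 nM in this assay, which is a limit of the assay rather than a number. Among the two compounds with a number, compound 2 stands lowest; its nearest neighbour is compound 1, whose number is higher by a margin beyond the usual scatter. One of the three results sits at the limit, as recorded in the limit of > 100000 nM in this assay, at which 1 of the 3 values shown sits.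

Compound 4 `CCc1cccc(-c2nn3c(c2-c2ccncc2)C(C)C(C)(C)C3)n1` has not yet been tested in this assay. The change from compound 2 to compound 4 is hydrogen in place of (4-sulfamoylphenyl)amino on an aromatic carbon. The group that leaves is absent from compound 1 and compound 3 as well. Because compound 1 without that group gives 92000 nM in this assay, a clear loss of potency is expected for compound 4. The step from compound 2 to compound 4 is expected to be an increase of about a 3.8-fold higher number from compound 2 to compound 4 (0.57 log units; beyond the scatter) in this assay. Compound 4 is therefore estimated at 90000 nM in this assay, with a likely range from 30000 nM to 250000 nM, and a fair chance that only a limit is reported.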

Compound 4, half-maximal inhibitory concentration: > 100000 nM
Compound 4: a limit, no number (the forecaster's own chance of this, stated with the estimate: 40%); at least 1.1-fold (0.04 log units) between middle value and limit.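

Among these compounds, for the first time, a single change at this position can be read on its own: on an aromatic carbon of a six-membered aromatic ring with 1 nitrogen, hydrogen in place of (4-sulfamoylphenyl)amino gives an at least 4.1-fold higher number from compound 2 to compound 4 (0.61 log units; beyond the scatter) in this assay. The earlier compounds shown here could not show this, since compound 2 alone carried the group and no measured compound differed from it in one place. The value of compound 4 is a limit, so the step gives only a minimum size, and compound 3 sits at the same limit: the limit of > 100000 nM in this assay, at which 2 of the 4 values shown sit.

The compounds shown leave open whether the effect belongs to the whole (4-sulfamoylphenyl)amino group or only to part of it, such as a plain phenylamino group without the sulfamoyl part or a simple amine on the same aromatic carbon. As far as these compounds go, it is equally open whether a carboxylic acid in place of the sulfamoyl part would keep the number of compound 2, 24000 nM in this assay.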